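The source may report more compounds than this note shows. Statements on the series, on what has been measured and on what is new or still open speak of the compounds shown alone.

Measured in a functional assay on K562 cells (Homo sapiens) for cytotoxicity, read by MTT assay, with a stated time of 48 h; on this read-out lower numbers stand for stronger inhibition and higher numbers for weaker inhibition:
- compound 1 `CCOC(=O)[C@@]1(C(=O)Nc2ccccc2Cl)C[C@@H]1c1cc(OC)c(OC)c(OC)c1`: 49400 nM
- compound 2 `COc1cc([C@H]2C[C@]2(CO)C(=O)Nc2ccccc2Cl)cc(OC)c1OC`: > 100000 nM

Compound 2 gives > 100000 nM, which is a limit of the assay and not a number. Compound 3 `CCOC(=O)[C@]1(C(=O)Nc2ccccc2Cl)C[C@@H]1c1cc(OC)c(OC)c(OC)c1` departs from compound 2 as follows: ethoxycarbonyl in place of hydroxymethyl on a saturated ring carbon. This places ethoxycarbonyl in place of hydroxymethyl on a saturated ring carbon. The expectation rests on compound 1, which also bears an ethoxycarbonyl and gives 49400 nM. In this assay a modest move towards stronger inhibition is expected, with an estimated at least 2.0-fold lower number from compound 2 to compound 3 (0.30 log units; that floor lies within the scatter). For compound 3 the expected value is 50000 nM, with an estimated range of 15000 nM to 100000 nM.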

Compound 3, half-maximal inhibitory concentration: 19500 nM
The estimate for compound 3 lay 2.6-fold (0.41 log units) above the measured number; the measured number falls inside the stated range.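

In this assay, ethoxycarbonyl in place of hydroxymethyl on this saturated ring carbon gives an at least 5.1-fold lower number from compound 2 to compound 3 (0.70 log units; beyond the scatter), so this position responds to the change. Compound 2 gives a limit of the assay and not a number, so the true size of that step stays unknown: the limit of > 100000 nM in this assay, at which 1 of the 3 values shown sits. Ethoxycarbonyl alone does not set the value, as there is also a 2.5-fold lower number from compound 1 to compound 3 (0.40 log units; beyond the scatter), a step that can be put down only to: the fact that compounds 1 and 3 differ only in the configuration as drawn

On these data alone, how a carboxylic acid or an amine on this ring carbon would read remains open. So does whether a longer chain in place of the ethyl of the ester would move the number further, and in which configuration.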